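A few compounds are considered here, and "the series" means these few. Any claim that something is new, unique, unknown or untested is made for them only; others in the source may bear on it.

Compound 1 `COc1cc(C)cc(-c2c(-c3ccnc(-c4ccc(N(C)C)cc4)c3)cnn2CC#N)c1` gives 57.7 nM in a functional assay on NCI-H460 cells (Homo sapiens) for inhibition, read by sulforhodamine B assay, with a stated time of 48 h; on this read-out lower numbers stand for stronger inhibition of growth and higher numbers for weaker inhibition of growth. Of the three compounds with a number, compound 1 stands lowest, so it is the strongest growth inhibitor shown. Compound 2 `COc1cc(C)cc(-c2nn(CC#N)cc2-c2ccnc(-c3ccc(N(C)C)cc3)c2)c1` gives 371 nM in this assay, a higher number that lies beyond the scatter, and compound 3 `COc1cc(C)cc(-c2nn(CC#N)cc2-c2ccc(-c3cccc(C(C)=O)c3)nc2)c1` gives 2040 nM, higher still and also beyond the scatter.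

Compound 4 `COc1cc(C)cc(-c2c(-c3ccnc(-c4ccc(C(C)=O)cc4)c3)cnn2CC#N)c1` has not been measured. It differs from compound 1 in a single place: acetyl in place of dimethylamino on an aromatic carbon. The rest of the shared core is unchanged, and the group that enters sits on an aromatic carbon of a six-membered aromatic ring of carbon only, para to a large group.

For the measured compounds named here, no measured pair shows exactly this exchange, so the expectation rests on the wider picture. The only compound with an acetyl group, compound 3, gives the highest number shown, namely 2040 nM, which points toward weaker growth inhibition once acetyl replaces dimethylamino. In this assay the expected step is a 4.3-fold higher number from compound 1 to compound 4 (0.64 log units; beyond the scatter), upward and beyond the scatter. Compound 4 is therefore estimated at 250 nM, with a likely range from 80 nM to 800 nM.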

Compound 4, concentration for 50% growth inhibition: 2410 nM
Compound 4: middle estimate off by 9.6-fold (0.98 log units), on the low side; measured number outside the range, above it.
By their numbers in this assay, from the lowest: compound 1; then compound 2; then compounds 3 and 4 (each within the scatter of the next).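

In this assay, this single exchange on an aromatic carbon, para to a large group, gives a 42-fold higher number from compound 1 to compound 4 (1.62 log units; beyond the scatter), so growth inhibition in this series depends strongly on the group at this position. The change is large even though the counts of heavy atoms, hydrogen-bond donors and hydrogen-bond acceptors stay the same on both sides and neither group carries a net charge; these counts alone therefore do not predict the outcome, and what matters must lie in some other difference between dimethylamino and acetyl. Nothing measured here says which difference is responsible for the step.

On these data alone, with only these two groups compared at this position, it remains open whether dimethylamino is unusually favourable or acetyl unusually unfavourable, and a simple amino group, a methoxy group or a carboxylic acid in the same place could help to separate the two possibilities. As far as these compounds go, it also remains open whether the exchange of dimethylamino for acetyl would produce a step of similar size on the core of compound 2.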